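Phenyl for 4-methoxybenzyl on the triazole nitrogen

A few compounds are considered here, and "the series" means these few. Any claim that something is new, unique, unknown or untested is made for them only; others in the source may bear on it.

Compound 2 `COc1ccc(Cn2c(CCc3ccccc3)nnc2[C@H](NC(=O)Cc2ccccn2)c2c[nH]c3ccccc23)cc1`: 3 nM
Compound 1 `CCc1ccc(Cn2c(CCc3ccccc3)nnc2[C@H](NC(=O)Cc2ccccn2)c2c[nH]c3ccccc23)cc1`: 51 nM

Two compounds share the core and differ only in one group on the benzyl ring. In an in vitro assay on LLC-PK1 cells for displacement of a labelled ligand from growth hormone secretagogue receptor type 1 (Homo sapiens) (a higher number here means a weaker inhibitor, a lower number a stronger inhibitor), compound 2 gives 3 nM, while compound 1 gives 51 nM. For the measured compounds named here, the single measured step, a 17-fold lower number from compound 1 to compound 2 (1.23 log units; beyond the scatter), shows that the group on the benzyl ring matters a great deal. On the numbers shown, compound 2 stands lowest of the two, with compound 1 as its only neighbour.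

Compound 3 `O=C(Cc1ccccn1)N[C@H](c1c[nH]c2ccccc12)c1nnc(CCc2ccccc2)n1-c1ccccc1` is not yet measured. It differs from compound 2 by phenyl in place of 4-methoxybenzyl on an aromatic nitrogen: the whole 4-methoxybenzyl group leaves and a bare phenyl takes its place. Going by the values given here, the step from compound 1 to compound 2 bears on it only indirectly, since it changed the group on that benzyl ring rather than removing the ring itself; no measured pair swaps a benzyl for a phenyl. Because the step of a 17-fold lower number from compound 1 to compound 2 (1.23 log units; beyond the scatter) was large, losing the methoxy-bearing benzyl is expected to cost, and compound 3 is estimated at 30 nM (range 5 nM to 200 nM), a step of a 10-fold higher number from compound 2 to compound 3 (1.00 log units; beyond the scatter) in this assay, with a wide range given the absence of a direct precedent.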

Compound 3, half-maximal inhibitory concentration: 700 nM
For compound 3 the middle estimate is 23-fold (1.37 log units) below the measured one; measured number above the stated range.
By their numbers in this assay, from the lowest: compound 2; then compound 1; then compound 3.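

In this assay, replacing either substituted benzyl with phenyl on the aromatic nitrogen is costly: the change gives a 230-fold higher number from compound 2 to compound 3 (2.37 log units; beyond the scatter) and a 14-fold higher number from compound 1 to compound 3 (1.14 log units; beyond the scatter). Compounds 1 and 2 differed only in the group carried on the benzyl ring, whereas compound 3 shows that this position also tolerates a change of the whole benzyl group poorly, even though a six-membered aromatic ring of carbon only remains on the nitrogen in all three compounds. Both benzyl compounds give lower numbers than compound 3, whichever of the two ring groups they carry, and no information on the reason for this is available here.

The change to phenyl removes the ring group and alters the link between the ring and the nitrogen in a single step, so the compounds shown do not separate these two contributions. An unsubstituted benzyl group and a methoxyphenyl group on this nitrogen would tell them apart, and a longer chain such as a 4-methoxyphenethyl group would show whether extending the link further is tolerated.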